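This account rests on a few compounds, and the source may have more. Where it says the series, first, only, none or still open, it means among the compounds named here.

In a functional assay on K562 cells (Homo sapiens) for cytotoxicity (on this read-out lower numbers stand for stronger inhibition of growth and higher numbers for weaker inhibition of growth), compound 1 (`OCCCCC#Cc1ccccc1C#Cc1cccs1`) gives 20300 nM and compound 2 (`OCCCCC#Cc1ccccc1C#Cc1cccc(O)c1`) gives 19200 nM. These two values lie within the scatter of each other, so compound 2 stands level with compound 1. Compound 3 (`OCCCCC#Cc1ccccc1C#Cc1ccc(O)cc1`) carries 4-hydroxyphenyl in place of the 3-hydroxyphenyl of compound 2 on a triple-bonded carbon: 4-hydroxyphenyl in place of 3-hydroxyphenyl on a triple-bonded carbon. Among the compounds with values here, only one measured step bears on this change, a 1.1-fold lower number from compound 1 to compound 2 (0.02 log units; within the scatter). That step replaced the whole group at the same place and stayed within the scatter. Within the data shown here, it is thin evidence, and no measured pair isolates a change of hydroxyl position. No shift beyond the scatter is therefore expected in this assay. The expected step is a 1.1-fold lower number from compound 2 to compound 3 (0.03 log units; within the scatter). For compound 3 the estimated value is 18000 nM, with an expected range of 8000 nM to 40000 nM.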

Compound 3, concentration for 50% growth inhibition: 20400 nM
Compound 3: middle estimate off by 1.1-fold (0.05 log units), on the low side; the range from low to high includes it.
By their numbers in this assay, from the lowest: compounds 2, 1 and 3 (each within the scatter of the next).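

In this assay the change of 4-hydroxyphenyl in place of 3-hydroxyphenyl on a triple-bonded carbon gives a step (a 1.1-fold higher number from compound 2 to compound 3 (0.03 log units; within the scatter)) that stays within the scatter, and this is the only pair shown that isolates a change of hydroxyl position. The step for 4-hydroxyphenyl in place of thiophen-2-yl at the same place (a 1.0-fold higher number from compound 1 to compound 3 (0.00 log units; within the scatter)) also stays within the scatter, so the three groups at this place stand level on this read-out. No measurement shown explains this level standing.

Still open, as far as these compounds go, is whether an amine, a carboxylic acid or a methoxy group at this place would give a step beyond the scatter. Also open, from the compounds shown here alone, is whether a longer chain in place of the hydroxyl-bearing chain of the shared core would do so.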